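Shifting a hydroxycarbamoyl ethenyl arm on a sulfonyl phenyl

The compounds below may be only part of what the source reports. "The series", "measured", "known", "first", "only" and "open" are said of these compounds alone.

Compound 1 `COc1cc(C(=O)c2ccc3c(ccn3S(=O)(=O)c3ccc(/C=C/C(=O)NO)cc3)c2)cc(OC)c1OC`: > 100000 nM
Compound 2 `O=C(NO)c1ccc(Cn2ccc3cc(C(=O)c4ccc(Cl)cc4)ccc32)cc1`: > 100000 nM

In an assay on isolated protein for inhibition of polyamine deacetylase HDAC10 (Homo sapiens) (a higher number here means a weaker inhibitor, a lower number a stronger inhibitor), compound 1 gives > 100000 nM, which is a limit of the assay and not a number. Compound 2 likewise reaches only > 100000 nM in this assay, again a limit rather than a measured value. Both sit at the limit of > 100000 nM in this assay, at which 2 of the 2 values shown sit. Compound 3 `COc1cc(C(=O)c2ccc3c(ccn3S(=O)(=O)c3cccc(/C=C/C(=O)NO)c3)c2)cc(OC)c1OC` has the same atoms as compound 1, joined differently: 3-(2-(hydroxycarbamoyl)ethenyl)phenyl in place of 4-(2-(hydroxycarbamoyl)ethenyl)phenyl on a sulfonyl sulfur. No step between measured compounds is shown, so nothing measured tells how large this kind of change is. The expected step of a number no higher from compound 1 to compound 3 (the limit leaves the size open) is none beyond the scatter. Compound 3 is therefore estimated at 100000 nM, within 30000 nM to 300000 nM, most probably reported only as a limit again.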

Compound 3, half-maximal inhibitory concentration: > 100000 nM
Compound 3 ended at the assay's limit (the forecaster's own chance of this, stated with the estimate: 80%); the middle value lies on the limit itself.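

For the compounds shown here, compound 1 and compound 3 both stand only at a limit in this assay, so no step between them can be read. The compounds shown leave open whether 3-(2-(hydroxycarbamoyl)ethenyl)phenyl or 4-(2-(hydroxycarbamoyl)ethenyl)phenyl on a sulfonyl sulfur gives the stronger inhibitor.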